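This account rests on a few compounds, and the source may have more. Where it says the series, first, only, none or still open, it means among the compounds named here.

Compound 1 `O=C(Nc1cc(C(F)(F)F)cc(C(F)(F)F)c1)c1cc(Cl)c(F)cc1O` gives 730 nM
Compound 2 `O=C(Nc1cc(C(F)(F)F)cc(C(F)(F)F)c1)c1cc(Br)c(F)cc1O` gives 700 nM
Compound 3 `O=C(Nc1ccc(Cl)c(C(F)(F)F)c1)c1cc(F)ccc1O` gives 530 nM

In a functional assay on Jurkat cells (Homo sapiens) for cytotoxicity, read by luminescence and CellTiter-Glo, with a stated time of 3 days (a lower number here means a stronger inhibitor, a higher number a weaker inhibitor), compound 2 at 700 nM lies within the scatter of both compound 1 and compound 3 so its place among the three is not settled. Going from compound 2 to the unmeasured compound 4 `O=C(Nc1cc(C(F)(F)F)cc(C(F)(F)F)c1)c1cc(Br)ccc1O` puts hydrogen in place of fluoro on an aromatic carbon and changes nothing else. For the measured compounds named here, no measured pair shows this change alone. Going by the values given here, the only measured step of a 1.0-fold lower number from compound 1 to compound 2 (0.02 log units; within the scatter) is bromo in place of chloro on an aromatic carbon and stays within the scatter, so it offers only loose guidance and no direction. The expected change is a 1.1-fold lower number from compound 2 to compound 4 (0.05 log units; within the scatter) with no shift beyond the scatter. The estimated value for compound 4 is 620 nM with an expected range from 280 nM to 1400 nM as its likely span.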

Compound 4, half-maximal inhibitory concentration: 350 nM
Beside the measured number, compound 4's estimate is 1.8-fold (0.25 log units) above it; the measured number falls inside the stated range.
By their numbers in this assay, from the lowest: compounds 4, 3, 2 and 1 (each within the scatter of the next, the first and the last beyond it).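

In this assay, hydrogen in place of fluoro on the aromatic carbon ortho to the bromo group and meta to the hydroxy group gives a 2.0-fold lower number from compound 2 to compound 4 (0.30 log units; within the scatter). For the compounds shown here, this is the first step that tests this position alone, and it shows that compound 4 stays within the scatter of compound 2 without the fluoro group. The compounds shown leave open whether a methoxy group or an amine at this place would move the number beyond the scatter, and whether the same swap behaves alike with chloro in place of bromo. No measurement given here accounts for this step.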